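Extending the sulfonamide chain of compound 1

A few compounds are considered here, and "the series" means these few. Any claim that something is new, unique, unknown or untested is made for them only; others in the source may bear on it.

Measured in a functional assay on A549 cells (Homo sapiens) for antiproliferative activity, read by CCK-8 assay, with a stated time of 72 h (a lower number here means a stronger inhibitor of growth, a higher number a weaker inhibitor of growth), so far:
compound 1 (`CCC1C(=O)N(C)c2cnc(Nc3ccc(S(=O)(=O)NC)cc3)nc2N1c1ccn(C)n1`) gives (12600 nM)
compound 2 (`CCCCNC(=O)c1ccc2c(ccn2-c2ncc3c(n2)N(c2ccn(C)n2)C(CC)C(=O)N3C)c1`) gives (37300 nM)

Compound 1 holds the lower of the two numbers, and its gap to compound 2 lies beyond the scatter. Compound 3 (`CCC1C(=O)N(C)c2cnc(Nc3ccc(S(=O)(=O)NCCCO)cc3)nc2N1c1ccn(C)n1`) keeps the core of compound 1 and turns methylsulfamoyl into (3-hydroxypropyl)sulfamoyl, with 2-hydroxyethyl in place of hydrogen on a saturated chain carbon bound to a sulfonamide nitrogen. Going by the values given here, no measured pair tests this change. In this assay the estimated step (a 1.3-fold lower number from compound 1 to compound 3 (0.10 log units; within the scatter)) is expected to stay within the scatter. For compound 3 the expected value is 10000 nM with an estimated range from 3000 nM to 30000 nM overall.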

Compound 3, concentration for 50% growth inhibition: 48900 nM
Compound 3: the middle estimate sits 4.9-fold (0.69 log units) below what was measured; the whole stated range lies below it.
By their numbers in this assay, from the lowest: compound 1; then compounds 2 and 3 (each within the scatter of the next).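

In this assay turning methylsulfamoyl into (3-hydroxypropyl)sulfamoyl gives a 3.9-fold higher number from compound 1 to compound 3 (0.59 log units; beyond the scatter) and so weakens growth inhibition. The saturated chain carbon bound to a sulfonamide nitrogen therefore does not accept this addition without loss, although a single pair speaks only for 2-hydroxyethyl at this place. Nothing available bears on the reason for this step. On these data alone, whether the loss follows the longer chain or its hydroxyl stays open. A plain propyl chain, or an amine or carboxylic acid on the same chain, would separate these two readings.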